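Pyridin-3-yl in place of 4-methoxyphenyl: cytotoxicity outlook

The compounds below may be only part of what the source reports. "The series", "measured", "known", "first", "only" and "open" are said of these compounds alone.

The series shares the core of compound 1 `Cc1ccc(-c2ccnc(Nc3ccc4c(c3)c(/C=C3/C(=O)Nc5ccccc53)cn4C)n2)cc1`, whose value in a functional assay on MCF7 cells (Homo sapiens) for cytotoxicity, read by MTT assay, with a stated time of 48 h (on this read-out lower numbers stand for stronger inhibition and higher numbers for weaker inhibition), is a limit of the assay at > 100000 nM. Compound 2 `COc1ccc(-c2ccnc(Nc3ccc4c(c3)c(/C=C3/C(=O)Nc5ccccc53)cn4C)n2)cc1` likewise gives only a limit in this assay, > 100000 nM. Compound 3 `Cn1cc(/C=C2/C(=O)Nc3ccccc32)c2cc(Nc3nccc(-c4ccc(Cl)cc4Cl)n3)ccc21` also sits at a limit in this assay, > 100000 nM. Compound 2 therefore stands where every measured compound of the series stands: the limit of > 100000 nM in this assay, at which 3 of the 3 values shown sit. The steps a step that the two limits leave unreadable from compound 1 to compound 2, a step that the two limits leave unreadable from compound 1 to compound 3 and a step that the two limits leave unreadable from compound 2 to compound 3 all remain unreadable between these limits.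

Compound 4 `Cn1cc(/C=C2/C(=O)Nc3ccccc32)c2cc(Nc3nccc(-c4cccnc4)n3)ccc21` differs from compound 2 as follows: pyridin-3-yl in place of 4-methoxyphenyl on an aromatic carbon. Going by the values given here, none of the measured steps has a readable size, and exchanging 4-methoxyphenyl for 4-methylphenyl or for 2,4-dichlorophenyl left each compound at the limit. No step beyond the scatter is therefore expected in this assay, and the step of a number no higher from compound 2 to compound 4 (the limit leaves the size open) is an estimate resting on those limits alone. Compound 4 is expected near 100000 nM, within 30000 nM to 300000 nM, most probably reported again as a limit.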

Compound 4, half-maximal inhibitory concentration: 46600 nM
Compound 4: the middle estimate sits 2.1-fold (0.33 log units) above what was measured; measured number inside the range.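

Pyridin-3-yl on this aromatic carbon is the first group in the series to give a number rather than a limit in this assay and it marks an at least 2.1-fold lower number from compound 2 to compound 4 (0.33 log units; beyond the scatter) and also an at least 2.1-fold lower number from compound 3 to compound 4 (0.33 log units; beyond the scatter) as well as an at least 2.1-fold lower number from compound 1 to compound 4 (0.33 log units; beyond the scatter) in the same direction. Going by these compounds, all three steps start from a limit, so the true sizes stay open, while the steps among compound 1, compound 2 and compound 3 cannot be read. Within these four compounds the position is therefore not silent in this read-out, and compound 4 alone has left the limit: the limit of > 100000 nM in this assay, at which 3 of the 4 values shown sit.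

The compounds shown do not separate the ring nitrogen of pyridin-3-yl from the smaller size of the entering group. Unsubstituted phenyl, pyridin-4-yl or pyridin-2-yl on this carbon would bear on that question, and whether any further gain is available here remains unknown.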